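From Diethylamino to Pyrrolidin-1-yl on One Chain Carbon

This account rests on a few compounds, and the source may have more. Where it says the series, first, only, none or still open, it means among the compounds named here.

In a functional assay on MCF7 cells (Homo sapiens) for antiproliferative activity, read by MTT assay, with a stated time of 48 h (on this read-out lower numbers stand for stronger inhibition and higher numbers for weaker inhibition), compound 1 `CC(C)=CCC[C@]1(C)/C=C/[C@@H](OC(=O)C=C(C)C)[C@](C)(O)/C=C/C(=O)/C(C=O)=C\C1` gives 12600 nM, compound 2 `CC(C)=CCC[C@]1(C)/C=C/[C@@H](OC(=O)C=C(C)C)[C@](C)(O)/C=C/C(=O)/C(CCl)=C\C1` gives 610 nM, and compound 3 `CCN(CC)C/C1=C/C[C@](C)(CCC=C(C)C)/C=C/[C@@H](OC(=O)C=C(C)C)[C@](C)(O)/C=C/C1=O` gives 130 nM, the lowest number of the three. Compound 4 `CC(C)=CCC[C@]1(C)/C=C/[C@@H](OC(=O)C=C(C)C)[C@](C)(O)/C=C/C(=O)/C(CN2CCCC2)=C\C1` differs from compound 3 in one group: pyrrolidin-1-yl in place of diethylamino on a saturated chain carbon bound to a double-bonded ring carbon. In words, pyrrolidin-1-yl stands in place of diethylamino on a saturated chain carbon bound to a double-bonded ring carbon.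

Among the compounds with values here, no measured step makes this exchange. The nearest evidence comes from changes around the same carbon: the large 21-fold lower number from compound 1 to compound 2 (1.32 log units; beyond the scatter), the large 97-fold lower number from compound 1 to compound 3 (1.99 log units; beyond the scatter), and the modest 4.7-fold lower number from compound 2 to compound 3 (0.67 log units; beyond the scatter). These show that the number can move with changes there, but none of them replaces one amino group with another. With compound 3 at 130 nM as the anchor, no shift beyond the scatter is expected in this assay, and no direction can be firmly assigned. The estimated change is a 1.3-fold higher number from compound 3 to compound 4 (0.12 log units; within the scatter), which stays within the scatter. Compound 4 is expected at 170 nM, with an estimated range from 60 nM to 500 nM.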

Compound 4, half-maximal inhibitory concentration: 220 nM
Estimate against measurement, compound 4: 1.3-fold (0.11 log units) below, and the stated range covers the measured number.
By their numbers in this assay, from the lowest: compounds 3 and 4 (each within the scatter of the next); then compound 2; then compound 1.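

In this assay the exchange gives a 1.7-fold higher number from compound 3 to compound 4 (0.23 log units; within the scatter) and so shows that this position accepts the five-membered pyrrolidin-1-yl ring in place of the open diethylamino group, with the same count of heavy atoms, without a shift beyond the scatter. Compound 4 also keeps an advantage over the other groups on this carbon, with a 2.8-fold lower number from compound 2 to compound 4 (0.44 log units; beyond the scatter) against chloro and a 57-fold lower number from compound 1 to compound 4 (1.76 log units; beyond the scatter) against formyl on the double-bonded ring carbon, so compound 3 is no longer the only amine shown to stand ahead of both. Nothing available explains why the two amines read alike.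

From the compounds shown here alone, whether a piperidin-1-yl, a morpholin-4-yl or a primary amine on the same chain carbon would read alike stays open. Only this one cell line is shown, so whether the two amines also match in other cells is open too.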